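Ester Variation in an Adenine Series: Cytotoxicity Notes

This account rests on a few compounds, and the source may have more. Where it says the series, first, only, none or still open, it means among the compounds named here.

Measured compounds:
compound 1 `CC(C)CCOC(=O)C(O)Cn1cnc2c(N)ncnc21` — 400 ug/mL
compound 2 `Nc1ncnc2c1ncn2CC(O)C(=O)OCc1ccco1` — 40 ug/mL
compound 3 `CCCCCOC(=O)C(O)Cn1cnc2c(N)ncnc21` — not yet measured

In a functional assay on PRK cells (Oryctolagus cuniculus) for cytotoxicity (on this read-out lower numbers stand for higher toxicity in this test and higher numbers for lower toxicity in this test), compound 1 gives 400 ug/mL, and compound 2 gives 40 ug/mL. Going by the values given here, compound 2 has the lowest of the two numbers in this assay; its nearest neighbour is compound 1 with a 10-fold lower number from compound 1 to compound 2 (1.00 log units; beyond the scatter) as the only step so far.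

Compound 3 differs from compound 2 as follows: butyl in place of furan-2-yl on a saturated chain carbon bound to an oxygen next to a carbonyl group. Among the compounds with values here, this is essentially the step from compound 1 to compound 2 run backwards, with a chain of the same kind re-entering in place of the ring, so the single step of a 10-fold lower number from compound 1 to compound 2 (1.00 log units; beyond the scatter) bears directly on it and is expected to be roughly reversed.

Compound 3 is therefore expected to return to the region of compound 1 in this assay, with an expected step of a 10-fold higher number from compound 2 to compound 3 (1.00 log units; beyond the scatter). The estimate for compound 3 is 400 ug/mL, with a range from 130 ug/mL to 1000 ug/mL.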

Compound 3, minimum cytotoxic concentration: 200 ug/mL
Estimate against measurement, compound 3: 2.0-fold (0.30 log units) above; the range from low to high includes it.
By their numbers in this assay, from the lowest: compound 2; then compounds 3 and 1 (each within the scatter of the next).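

In this assay the pentyl chain gives a 5.0-fold higher number from compound 2 to compound 3 (0.70 log units; beyond the scatter), so the low number of compound 2 is not shared by this unbranched saturated chain at the same place. Between the two saturated chains the step is a 2.0-fold lower number from compound 1 to compound 3 (0.30 log units; within the scatter) and stays within the scatter, so the branched and unbranched forms cannot be told apart here, and among these three compounds only the furan-2-yl compound stands apart. Nothing at hand explains why the furan-2-yl compound differs from the two chains.

From the compounds shown here alone, with a single ring compound, it remains open whether the lower number belongs to furan-2-yl in particular or to rings in general, and a benzyl ester would separate the two. Going by these compounds, how the number responds to chain length also remains open, for example with an ethyl or an octyl ester.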